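Cytotoxicity notes: thiophene for difluorophenyl on the ether chain

The source may report more compounds than this note shows. Statements on the series, on what has been measured and on what is new or still open speak of the compounds shown alone.

The series rests on a shared core, seen in compound 1 `Cc1nc(C)c([C@H](OC(C)(C)C)C(=O)O)c(N2CCC(C)(C)CC2)c1-c1ccc(Oc2ccccc2)cc1` and compound 2 `Cc1nc(C)c([C@H](OC(C)(C)C)C(=O)O)c(N2CCC(C)(C)CC2)c1-c1ccc(OCCc2cc(F)ccc2F)cc1`. In a toxicity assay on MT2 cells (Homo sapiens) for cytotoxicity, read by XTT assay, with a stated time of 4 days (a higher number here means that more compound is tolerated, a lower number that less compound is tolerated), compound 1 reaches only a limit of the assay, >= 20000 nM. In this assay compound 2 likewise reaches only a limit, >= 33500 nM. Among the compounds with values here, the one measured step, a step that the two limits leave unreadable from compound 1 to compound 2, therefore cannot be read for size; both values sit at limits, as the limit of >= 20000 nM in this assay, at which 1 of the 2 values shown sits, and the limit of >= 33500 nM in this assay, at which 1 of the 2 values shown sits, record, so compound 2 stands at a limit and not at a number in this assay.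

Compound 3 `Cc1ccc(CCOc2ccc(-c3c(C)nc(C)c([C@H](OC(C)(C)C)C(=O)O)c3N3CCC(C)(C)CC3)cc2)s1` is not yet measured in this assay. It differs from compound 2 as follows: 5-methylthiophen-2-yl in place of 2,5-difluorophenyl on a saturated chain carbon, two bonds along the chain from an oxygen on an aromatic ring. Within the data shown here, no measured step bears on this change, and the single step known is itself unreadable. No step beyond the scatter is therefore expected in this assay from compound 2 to compound 3, and the expected step of an at least 1.1-fold lower number from compound 2 to compound 3 (0.04 log units; that floor lies within the scatter) is set close to nil. Compound 3 is estimated to give 30000 nM, within 15000 nM to 60000 nM, and is expected most likely to return another limit rather than a number.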

Compound 3, half-maximal cytotoxic concentration: >= 25000 nM
Compound 3: only a limit was reported (the forecaster's own chance of this, stated with the estimate: 80%); the middle value lies beyond the limit too.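

Compound 3 also gives only a limit in this assay, >= 25000 nM. Its steps from compound 1 and from compound 2 cannot be read, so no size can be given for either change. The compounds shown leave open whether any of these groups on the ether oxygen would give a cytotoxic concentration as a number rather than a limit.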